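Replacing a bromophenyl by a dinitrophenyl on the triazole nitrogen

The source may hold more compounds than are shown below. What is called first, only, known or untested is meant among the compounds shown, and "the series" means these compounds.

Measured so far in a functional assay on A549 cells (Homo sapiens) for antiproliferative activity, read by MTT assay, with a stated time of 48 h; a lower number here means a stronger inhibitor, a higher number a weaker inhibitor:
Compound 1 `N#CC1=C(N)Oc2c(c3nc4ccccc4nc3c3ccccc23)C12C(=O)N(Cc1cnnn1-c1ccc(Br)cc1)c1ccccc12` gives 44300 nM.
Compound 2 `N#CC1=C(N)Oc2c(c3nc4ccccc4nc3c3ccccc23)C12C(=O)N(Cc1cnnn1-c1ccccc1Br)c1ccccc12` gives > 50000 nM, which is a limit of this assay and not a number.
Compound 3 `N#CC1=C(N)Oc2c(N)cc3nc4ccccc4nc3c2C12C(=O)N(Cc1cnnn1-c1ccccc1Br)c1ccccc12` gives 27400 nM.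

Compound 3 stands with the smaller of the two numbers shown, but its nearest neighbour is compound 1, and the gap between them lies within the scatter, so nothing separates the two. Compound 2 sits at the limit, as the evidence shows (the limit of > 50000 nM in this assay, at which 1 of the 3 values shown sits).

Compound 4 `N#CC1=C(N)Oc2c(N)cc3nc4ccccc4nc3c2C12C(=O)N(Cc1cnnn1-c1ccc([N+](=O)[O-])cc1[N+](=O)[O-])c1ccccc12` differs from compound 3 in one place: 2,4-dinitrophenyl in place of 2-bromophenyl on an aromatic nitrogen. Among the measured compounds shown here, the only measured step that touches the same aromatic nitrogen is the move from one bromophenyl to the other, and that step, an at least 1.1-fold higher number from compound 1 to compound 2 (0.05 log units; that floor lies within the scatter), was itself at a floor that lies within the scatter. For the measured compounds named here, no measured pair shows a nitro group entering anywhere, so there is no step that bears directly on this change. In this assay the account therefore expects no step beyond the scatter, and compound 4 is estimated at 30000 nM, within 10000 nM to 100000 nM, which means an expected step of a 1.1-fold higher number from compound 3 to compound 4 (0.04 log units; within the scatter).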

Compound 4, half-maximal inhibitory concentration: > 50000 nM
Compound 4: a limit, no number; the forecaster's own chance of this, stated with the estimate: 35%; middle value at least 1.6-fold (0.22 log units) away from the limit.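

In this assay compound 4 gives > 50000 nM, which is a limit of the assay and not a number. The step reads an at least 1.8-fold higher number from compound 3 to compound 4 (0.26 log units; that floor lies within the scatter), so on this core the triazole nitrogen, which held a number with 2-bromophenyl, now also carries a group that ends at the limit, although the floor of the step alone does not establish a change beyond the scatter. The earlier compounds shown here showed a limit at this nitrogen only on the other core, and the limit now appears on both cores: the limit of > 50000 nM in this assay, at which 2 of the 4 values shown sit.

How far compound 4 really lies from compound 3 stays open, and the change removes the bromine and brings in both nitro groups at once, so the compounds shown cannot assign the result to any one of these parts. Also open, as far as these compounds go, is whether a phenyl carrying a single nitro group, an amine or a carboxylic acid at this nitrogen would give a number in this assay on this core.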